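The compounds below may be only part of what the source reports. "The series", "measured", "known", "first", "only" and "open" are said of these compounds alone.

In a functional assay on U-251 cells (Homo sapiens) for antiproliferative activity, read by MTT assay, with a stated time of 48 h (a higher number here means a weaker inhibitor, a lower number a stronger inhibitor), three compounds with a shared core have been measured. Compound 1 `COc1ccc(-c2nc3cccc(-c4cc(OC)c(OC)c(OC)c4)c3o2)cc1` gives > 25000 nM, which is a limit of the assay and not a number. Compound 2 `COc1cc(-c2cccc3nc(-c4cccc(C)c4)oc23)cc(OC)c1OC` gives > 25000 nM, also a limit. Within the data shown here, compound 3 `COc1cc(-c2cccc3nc(-c4cccc(N)c4)oc23)cc(OC)c1OC` gives 2200 nM, the only true number among the three.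

Compound 4 `COc1cc(-c2cccc3nc(-c4ccc5cc[nH]c5c4)oc23)cc(OC)c1OC` replaces the 3-aminophenyl of compound 3 with 1H-indol-6-yl: 1H-indol-6-yl in place of 3-aminophenyl on an aromatic carbon. Like 3-aminophenyl, 1H-indol-6-yl has 1 hydrogen-bond donor, but the amino group itself is gone.

Among the measured compounds shown here, two measured steps bear on this change, and both are large. Replacing 4-methoxyphenyl with 3-aminophenyl gives an at least 11-fold lower number from compound 1 to compound 3 (1.05 log units; beyond the scatter). Putting amino in place of methyl gives an at least 11-fold lower number from compound 2 to compound 3 (1.05 log units; beyond the scatter). On these data alone, both start from the limit of > 25000 nM in this assay, at which 2 of the 3 values shown sit, so their true sizes remain open. As compound 4 loses the amino group that marks these steps, part of that gain may be lost, though the retained donor could preserve some of it. The estimated step is a 2.7-fold higher number from compound 3 to compound 4 (0.44 log units; beyond the scatter), a moderate move towards a weaker inhibitor. Compound 4 is expected at about 6000 nM, within an estimated range of 1500 nM to 20000 nM.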

Compound 4, half-maximal inhibitory concentration: 300 nM
Estimate against measurement, compound 4: 20-fold (1.30 log units) above; the whole stated range lies above it.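

In this assay, an amino group is not required at this position for a stronger result: 1H-indol-6-yl, which has no amino group but does keep a hydrogen-bond donor, gives a 7.3-fold lower number from compound 3 to compound 4 (0.87 log units; beyond the scatter). Against the two groups that gave no measurable number, the change gives an at least 83-fold lower number from compound 2 to compound 4 (1.92 log units; beyond the scatter) and an at least 83-fold lower number from compound 1 to compound 4 (1.92 log units; beyond the scatter). Both of these sizes are only minimum sizes, since each step starts from a limit and not from a number: the limit of > 25000 nM in this assay, at which 2 of the 4 values shown sit.

The compounds shown leave open whether the gain comes from the hydrogen on the indole nitrogen or from the added five-membered aromatic ring. A 1-methylindole or a benzofuran in the same place would help separate these two possibilities, since each keeps the fused rings but lacks that hydrogen.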